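Moving the Pyridine Nitrogen: Oral Exposure of Compound 3

The compounds below may be only part of what the source reports. "The series", "measured", "known", "first", "only" and "open" are said of these compounds alone.

Measured compounds:
compound 1 `Cc1ccc(CNC2(CCC(C)(C)C)C(=O)C(C3=NS(=O)(=O)c4cc(NS(C)(=O)=O)ccc4N3)=C(O)c3ccccc32)cn1`: 0%
compound 2 `CC(C)CC[C@@]1(N)C(=O)C(C2=NS(=O)(=O)c3cc(NS(C)(=O)=O)ccc3N2)=C(O)c2ccccc21`: 0%

In an in vivo ADME assay on the whole organism (strain Sprague-Dawley) for pharmacokinetics, with Rattus norvegicus as the target, at a dose of 5 mg/kg by the oral route (a higher number here means that a larger share of the oral dose reaches the circulation, a lower number that a smaller share of the oral dose reaches the circulation), compound 1 gives 0%. In the same this assay compound 2 gives 0%. Compound 1 thus stands level with compound 2 at the digits shown, with no difference beyond the scatter between them; both sit at the floor of the read-out, where no share of the oral dose is seen in the circulation.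

Compound 3 `Cc1cccc(CNC2(CCC(C)(C)C)C(=O)C(C3=NS(=O)(=O)c4cc(NS(C)(=O)=O)ccc4N3)=C(O)c3ccccc32)n1` differs from compound 1 in one place only: 6-methylpyridin-2-yl in place of 6-methylpyridin-3-yl on a saturated chain carbon bound to an amine nitrogen. The two compounds have the same atoms, joined differently.

Going by the values given here, no step between measured compounds that differ in one place is available, so nothing measured tells how this kind of rearrangement moves oral bioavailability. What the two values show is a floor that neither compound leaves. On that basis the expected step in this assay is none beyond the scatter, in no particular direction, and the step that this estimate means is a number 1 percentage points higher from compound 1 to compound 3 (within the scatter). Compound 3 is therefore expected to give 1%, with a range from 0% to 10%.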

Compound 3, oral bioavailability: 33.8%
The estimate for compound 3 lay 32.8 percentage points below the measured number; the whole stated range lies below it.
By their numbers in this assay, from the lowest: compounds 1 and 2 (each within the scatter of the next); then compound 3.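

Exchanging 6-methylpyridin-3-yl for 6-methylpyridin-2-yl, on a saturated chain carbon bound to an amine nitrogen, gives in this assay a number 33.8 percentage points higher from compound 1 to compound 3 (beyond the scatter) and lifts compound 3 clear of the floor at which compound 1 sits. This position is therefore not indifferent to how the pyridine is joined: oral bioavailability moves sharply even though the two groups have the same heavy atoms, the same hydrogen-bond donor and acceptor counts and no net charge. Nothing at hand bears on what lies behind this step.

This single pair cannot separate the effect of the changed ring attachment from any part played by the methyl group, and an unsubstituted pyridin-2-yl or a phenyl ring in the same place would bear directly on that question. Going by these compounds, it also remains open whether the step would persist with an ethyl group, a methoxy group or a carboxylic acid in place of that methyl, or whether it holds only for the 6-methylpyridin-2-yl group of compound 3.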